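Swapping nitro for chloro in compound 3

The source may report more compounds than this note shows. Statements on the series, on what has been measured and on what is new or still open speak of the compounds shown alone.

Compound 1 `COc1ccc(C2CC(Nc3nc4ccc(C)cc4s3)=NN2C(C)=O)cc1` gives 37.3 umol/kg
Compound 2 `CC(=O)N1N=C(Nc2nc3ccc(Cl)cc3s2)CC1c1ccccc1` gives 161 umol/kg
Compound 3 `COc1ccc(/C=C/C(=O)Nc2nc3ccc([N+](=O)[O-])cc3s2)cc1O` gives 372 umol/kg

In a functional assay on the whole organism (Hindlimb, strain albino) with Mus musculus as the target, in the maximal electroshock model, with a stated time of 0.5 h (on this read-out lower numbers stand for an effect already at smaller amounts and higher numbers for an effect only at larger amounts of compound), compound 3 gives 372 umol/kg as the highest of the three numbers, and its gap to each of the other two compounds lies beyond the scatter. The next compound to consider is compound 4 `COc1ccc(/C=C/C(=O)Nc2nc3ccc(Cl)cc3s2)cc1O` which differs from compound 3 in one place. The change chloro in place of nitro on an aromatic carbon is chloro in place of nitro on an aromatic carbon, and the rest of the structure stays the same.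

Among the measured compounds shown here, no measured pair shows this swap on its own, so the expectation rests on thin evidence. Compound 2 also carries a chloro group and gives 161 umol/kg in this assay but the rest of its structure differs from compound 3, which makes it only a loose guide. A modest move towards a lower number is expected, and the estimated size is a 2.2-fold lower number from compound 3 to compound 4 (0.34 log units; beyond the scatter) in this assay for this single swap. The estimated value for compound 4 is 170 umol/kg with 60 umol/kg to 420 umol/kg as the expected span.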

Compound 4, dose for half-maximal effect: 320 umol/kg
Compound 4: middle estimate off by 1.9-fold (0.27 log units), on the low side; low and high end bracket the measured number.
By their numbers in this assay, from the lowest: compound 1; then compounds 2, 4 and 3 (each within the scatter of the next, the first and the last beyond it).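

Replacing nitro with chloro on this aromatic carbon gives a 1.2-fold lower number from compound 3 to compound 4 (0.07 log units; within the scatter) in this assay, so the two compounds cannot be told apart on this read-out. This is the first comparison shown that isolates this position, and it indicates that, on this core, nitro and chloro serve equally well here, even though nitro brings hydrogen-bond acceptors and chloro brings none. Nothing measured here explains this result.

Two groups at one position cannot show whether the position is insensitive in general, so an amine or a carboxylic acid on the same carbon could still separate from compound 3 and compound 4. On these data alone, it also remains open whether the same swap would behave alike on the core of compound 2, which carries chloro at a comparable place but has no nitro partner.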